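This account rests on a few compounds, and the source may have more. Where it says the series, first, only, none or still open, it means among the compounds named here.

Compound 1 `CCN(CC)CN1C(=O)/C(=N/NC(=S)Nc2ccc(Cl)cc2)c2ccccc21` is the reference of this set. In an ADME assay on HEL cells (Homo sapiens) for cytotoxicity (a higher number here means that more compound is tolerated, a lower number that less compound is tolerated), compound 1 gives 100000 nM. Compound 3 `CCN(CC)CN1C(=O)/C(=N/NC(=S)Nc2ccc(C)cc2)c2cc(Cl)ccc21` gives 100000 nM in this assay, level with compound 1 at the digits shown and within the scatter. Compound 2 `CCN(CC)CN1C(=O)/C(=N/NC(=S)Nc2ccccc2)c2ccccc21` gives in this assay a limit of the assay, > 100000 nM, and not a number. The step from compound 1 to compound 2 a number no lower from compound 1 to compound 2 (the limit leaves the size open) therefore reads as a number no lower, its size left open because of the limit of > 100000 nM in this assay, at which 1 of the 3 values shown sits.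

Compound 4 `CCN(CC)CN1C(=O)/C(=N/NC(N)=S)c2ccccc21` differs from compound 1 by hydrogen in place of 4-chlorophenyl on an amide-type nitrogen. Among the compounds with values here, no measured step removes the whole 4-chlorophenyl; the only related step, a number no lower from compound 1 to compound 2 (the limit leaves the size open), removes the chloro on an aromatic carbon alone and gives no readable size. The three measured values all sit at or at the top of the range covered. Compound 4 is thus expected to show a step of no change at the digits printed from compound 1 to compound 4 (within the scatter), none beyond the scatter. Compound 4 is estimated in this assay at 100000 nM, with a range from 50000 nM to 200000 nM.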

Compound 4, minimum cytotoxic concentration: > 100000 nM
Compound 4 gave a limit, no number; the forecaster's own chance of this, stated with the estimate: 50%; the middle value lies on the limit itself.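

With the whole 4-chlorophenyl replaced by hydrogen on the amide-type nitrogen, this assay shows a number no lower from compound 1 to compound 4 (the limit leaves the size open), so this change reaches further than the loss of chloro alone and the aromatic ring at this position is not needed to keep the reading at the top of the range. The steps involving only limits, including that between compound 2 and compound 4, cannot be read. The size of any gain stays hidden because of the assay limit: the limit of > 100000 nM in this assay, at which 2 of the 4 values shown sit.

On these data alone, what a different substituent on this nitrogen does remains open, for example a longer chain such as n-butyl or a benzyl group. A carboxylic acid or a dimethylamino group on the phenyl ring of compound 2 is likewise untested by these values, which do not show what would bring the reading below the limit.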